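Ring contraction on the side chain of compound 2

The source may report more compounds than this note shows. Statements on the series, on what has been measured and on what is new or still open speak of the compounds shown alone.

Three compounds of the shared core have numbers in an assay on CHO cells for displacement of a labelled ligand from adenosine receptor A1 (Homo sapiens); on this read-out lower numbers stand for stronger inhibition and higher numbers for weaker inhibition. Compound 1 `CCNC(=O)[C@H]1O[C@@H](n2cnc3c(NC)nc(-n4cc(Cc5ccccc5)nn4)nc32)[C@H](O)[C@@H]1O` gives 510 nM. Compound 3 `CNc1nc(-c2cn(Cc3cccc(Cl)c3)nn2)nc2c1ncn2[C@@H]1O[C@H](CO)[C@@H](O)[C@H]1O` gives 956 nM. Compound 2 `CNc1nc(-n2cc(CC3CCCCC3)nn2)nc2c1ncn2[C@@H]1O[C@H](CO)[C@@H](O)[C@H]1O` gives 1430 nM, the highest number of the three; the gap from compound 2 to compound 3 lies within the scatter, while the gap from compound 2 to compound 1 lies beyond it, so compound 1 is the only one of the three with a clearly lower number than compound 2. Among the compounds with values here, no pair among the three differs in a single place, so no measured step exists for the change that leads to compound 4 `CNc1nc(-n2cc(CC3CCCC3)nn2)nc2c1ncn2[C@@H]1O[C@H](CO)[C@@H](O)[C@H]1O`. The change from compound 2 to compound 4 is cyclopentyl in place of cyclohexyl on a saturated chain carbon bound to an aromatic carbon. Nothing measured supports a direction for this change, and the expected step of a 1.1-fold lower number from compound 2 to compound 4 (0.06 log units; within the scatter) is small, not beyond the scatter either way. Compound 4 is estimated at 1250 nM in this assay, with a range from 500 nM to 3200 nM.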

Compound 4, inhibition constant: 335 nM
Estimate against measurement, compound 4: 3.7-fold (0.57 log units) above, and the stated range ends above it.
By their numbers in this assay, from the lowest: compounds 4, 1, 3 and 2 (each within the scatter of the next, the first and the last beyond it).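

In this assay, within the data shown here, cyclopentyl in place of cyclohexyl gives a 4.3-fold lower number from compound 2 to compound 4 (0.63 log units; beyond the scatter) and so provides the first measured step at this position, on a saturated chain carbon bound to an aromatic carbon. With everything else in the two structures unchanged, a ring of five carbons in place of a ring of six is enough to move the number beyond the scatter. Nothing available accounts for the size or direction of this step.

As far as these compounds go, whether the step continues to a smaller ring such as cyclobutyl or cyclopropyl, or extends to an open chain such as isobutyl, remains open. This single pair also leaves open whether the same ring change would shift the number on a compound carrying the ethyl amide of compound 1.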